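A few compounds are considered here, and "the series" means these few. Any claim that something is new, unique, unknown or untested is made for them only; others in the source may bear on it.

Measured so far:
- Compound 1, `CCCn1c(=O)c2nc(-c3ccccc3N)[nH]c2n(CCC)c1=O`: 0.75 nM
- Compound 2, `CCn1c(=O)c2nc(-c3ccc(S(=O)(=O)N4CCSCC4)cc3)[nH]c2n(CC)c1=O`: 36.6 nM

In an assay for binding affinity to adenosine receptor A1 (Bos taurus) (on this read-out lower numbers stand for stronger inhibition and higher numbers for weaker inhibition), compound 1 gives the lower of the two numbers shown, and compound 2 gives a number far higher than that of compound 1, a gap well beyond the usual scatter of repeated measurements. The two compounds differ in several places at once, so nothing can be read from them about any single change; the comparison only shows that compound 1 is the more tightly binding of the pair.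

Compound 3, `CCCn1c(=O)c2nc(-c3ccc(Cl)cc3N)[nH]c2n(CCC)c1=O`, is the compound still to be measured. It differs from compound 1 in one place: chloro in place of hydrogen on an aromatic carbon. In other words, chloro takes the place of hydrogen on an aromatic carbon, meta to an amino group and para to a large group, so that the 2-aminophenyl becomes a 2-amino-4-chlorophenyl.

Among the compounds with values here, no pair of measured compounds shows the effect of this particular change, so the expectation can rest only on the strong binding of compound 1. The step from compound 1 to compound 3 is expected to be small, a 1.3-fold higher number from compound 1 to compound 3 (0.12 log units; within the scatter), with no clear direction beyond the scatter. For compound 3 the expected value in this assay is therefore 1 nM, within a range from 0.3 nM to 4 nM.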

Compound 3, half-maximal inhibitory concentration in the adenosine receptor A1 assay: 0.05 nM
Beside the measured number, compound 3's estimate is 20-fold (1.30 log units) above it; the whole stated range lies above it.
By their numbers in the adenosine receptor A1 assay, from the lowest: compound 3; then compound 1; then compound 2.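

At this position, on an aromatic carbon meta to an amino group and para to a large group, adding chloro has a large effect on binding: in the adenosine receptor A1 assay there is a 15-fold lower number from compound 1 to compound 3 (1.18 log units; beyond the scatter). This shows that the position tolerates chloro and that binding gains from it, which compounds 1 and 2 could not show, as they differ in several places at once. The same change also alters the acid dissociation measured in a physicochemical assay for acid dissociation, with the proton given up more readily in compound 3: the measured acid dissociation constant of compound 1, 9.1, and of compound 3, 8.4, a number 0.70 log units lower (beyond the scatter). In the physicochemical assay compound 1 gives 9.1, and compound 3 gives 8.4.

The two shifts arrive together in one change, and this single pair cannot tell whether the easier loss of the proton accounts for the stronger binding, or whether the two are unrelated. On these data alone, it also remains open whether the gain is specific to chloro or would also appear with fluoro, a methyl group or a methoxy group on the same carbon, and whether a different position on the ring would respond in the same way.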